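Trimming benzyl to ethyl on the thioether of compound 3

This account rests on a few compounds, and the source may have more. Where it says the series, first, only, none or still open, it means among the compounds named here.

Compound 3 `O=c1c2ccccc2[se]n1-c1nc(SCc2ccccc2)n[nH]1` stands second highest of the three numbers in a functional assay on SMMC-7721 cells (Homo sapiens) for antiproliferative activity, read by CCK-8 assay, with a stated time of 48 h (a higher number here means a weaker inhibitor, a lower number a stronger inhibitor), where compound 3 gives 32000 nM. Its nearest neighbour is compound 2 `Cc1ccccc1CSc1n[nH]c(-n2[se]c3ccccc3c2=O)n1`, which in this assay gives 36200 nM; the step of a 1.1-fold lower number from compound 2 to compound 3 (0.05 log units; within the scatter) lies within the scatter. Furthest from it stands compound 1 `CC(C)Sc1n[nH]c(-n2[se]c3ccccc3c2=O)n1`, which gives 6010 nM in this assay, a step of a 5.3-fold higher number from compound 1 to compound 3 (0.73 log units; beyond the scatter).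

Compound 4 `CCSc1n[nH]c(-n2[se]c3ccccc3c2=O)n1` differs from compound 3 by methyl in place of phenyl on a saturated chain carbon bound to a sulfur, so the chain on the sulfur shrinks back toward the small alkyl of compound 1. Going by the values given here, the steps that bear on this are a 5.3-fold higher number from compound 1 to compound 3 (0.73 log units; beyond the scatter) and a 6.0-fold higher number from compound 1 to compound 2 (0.78 log units; beyond the scatter): both times, going from a small alkyl on the sulfur to a benzyl-type group raised the number by a modest amount beyond the scatter. Reversing that direction, compound 4 is therefore expected to show a modest decrease in this assay, a step of about a 4.6-fold lower number from compound 3 to compound 4 (0.66 log units; beyond the scatter), landing near the number of compound 1. The estimate for compound 4 in this assay is 7000 nM, with a range from 3000 nM to 18000 nM.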

Compound 4, half-maximal inhibitory concentration: 10000 nM
Compound 4: middle estimate off by 1.4-fold (0.15 log units), on the low side, and the stated range covers the measured number.
By their numbers in this assay, from the lowest: compounds 1 and 4 (each within the scatter of the next); then compounds 3 and 2 (each within the scatter of the next).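

Taking the phenyl off the sulfur chain lowers the number in this assay (see a 3.2-fold lower number from compound 3 to compound 4 (0.51 log units; beyond the scatter)) and removing the 2-methylphenyl does the same (see a 3.6-fold lower number from compound 2 to compound 4 (0.56 log units; beyond the scatter)), so the gap that had been seen only against the isopropyl of compound 1 also appears against a straight ethyl chain. Ethyl and isopropyl themselves cannot be told apart (see a 1.7-fold higher number from compound 1 to compound 4 (0.22 log units; within the scatter)), so the four compounds fall into two groups at this position, the small alkyl thioethers compound 1 and compound 4 and the benzyl-type thioethers compound 2 and compound 3, and none of the four goes against this division. Nothing available explains why the aromatic ring on this chain carries this cost in these cells.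

The compounds shown leave open how a plain methyl, a longer chain such as butyl or a saturated ring such as cyclohexylmethyl on the sulfur would read, and so whether the rise in the number follows chain length or the aromatic ring itself. They also leave open what an amine or a carboxylic acid at the end of the chain would do.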